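The compounds below may be only part of what the source reports. "The series", "measured", "known", "first", "only" and "open" are said of these compounds alone.

In a functional assay on brain (Rattus norvegicus, strain Wistar) for inhibition (on this read-out higher numbers stand for weaker inhibition and lower numbers for stronger inhibition), compound 2 `Cc1ccc(-c2c(C)[nH]c(=O)n2C)cc1` gives 85300 nM, the higher of the two numbers recorded, with compound 1 `CCCCc1ccc(-c2c(C)[nH]c(=O)n2C(C)C)cc1` at 10700 nM showing the lower one. Compound 3 `CCCCCCCCCCCCCCCCCCOc1ccc(-c2c(C)[nH]c(=O)n2C)cc1` reaches only a limit of this assay, > 100000 nM; it is the limit of > 100000 nM in this assay, at which 1 of the 3 values shown sits. Compound 4 `Cc1[nH]c(=O)n(C)c1-c1ccc(Oc2ccccc2)cc1` has not yet been measured in this assay. It differs from compound 2 by phenoxy in place of methyl on an aromatic carbon. Among the measured compounds shown here, no measured pair on record shows the same change, so its effect is open; from compound 2 to compound 4 a step of a 2.1-fold lower number from compound 2 to compound 4 (0.33 log units; beyond the scatter) toward stronger inhibition is expected, but not one that can be held to with confidence. For compound 4 in this assay a value of 40000 nM is estimated, expected to fall between 8000 nM and 200000 nM.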

Compound 4, half-maximal inhibitory concentration: 8100 nM
Beside the measured number, compound 4's estimate is 4.9-fold (0.69 log units) above it; the range from low to high includes it.
By their numbers in this assay, from the lowest: compounds 4 and 1 (each within the scatter of the next); then compound 2. At a limit, above all of these: compound 3.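

In this assay, the aromatic carbon para to a group of 8 heavy atoms proves able to carry a much larger group with a gain, a large step: an 11-fold lower number from compound 2 to compound 4 (1.02 log units; beyond the scatter). Compound 3, with an octadecyloxy chain at the same place, stands at a limit of the assay: the limit of > 100000 nM in this assay, at which 1 of the 4 values shown sits. An oxygen attached at this place therefore does not bring the gain on its own, since only the phenoxy of compound 4 shows it.

Going by these compounds, what a shorter chain such as butoxy, or an amine, would do at this place stays open. Compound 1 differs from compound 2 in two places, so the contributions of its butyl and isopropyl groups remain unseparated.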